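Chloro in place of methoxymethyl on the aryl ring

The source may report more compounds than this note shows. Statements on the series, on what has been measured and on what is new or still open speak of the compounds shown alone.

Measured compounds:
compound 1 `COCc1ccccc1C1CCc2nc[nH]c2C1` — 87%; 83% (2 entries)
compound 2 `COCc1ccccc1C1Cc2nccn2C1` — 77%
compound 3 `COc1cccc(C2CCc3nc[nH]c3C2)c1` — 60%

All three were tested in a functional assay on CHO cells for agonist activity at Alpha-1A adrenergic receptor (Homo sapiens), read by FLIPR and calcium flux; on this read-out higher numbers stand for larger maximal responses and lower numbers for smaller maximal responses. Compound 1 was run twice, and its two entries, (the several entries of compound 1 in this assay, 87%; 83% (2 entries)), fall within the usual scatter of each other and of the value of compound 2. Compound 3 gives 60% in this assay, a number that lies below compound 2 by more than the scatter, so compound 2 stands clearly above compound 3, while it cannot be separated from compound 1.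

The next step leaves compound 2 and goes to compound 4 `Clc1ccccc1C1Cc2nccn2C1`. The change is chloro in place of methoxymethyl on an aromatic carbon. For the measured compounds named here, since no measured pair shows this exchange, its effect is unknown; as the aryl ring is substituted at the same place in both compounds, the expected step in this assay is small, at most a modest decrease and possibly none beyond the scatter, so that the step from compound 2 to compound 4 is estimated as a number 5 percentage points lower from compound 2 to compound 4 (within the scatter). Compound 4 is therefore expected to give about 72%, with a likely range from 50% to 92%.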

Compound 4, largest response reached (Emax), in percent of the reference or control that the assay uses: 56%
Compound 4: middle estimate off by 16 percentage points, on the high side, within the range that was stated.
By their numbers in this assay, from the lowest: compounds 4 and 3 (each within the scatter of the next); then compound 2.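

In this assay, chloro in place of methoxymethyl on this aromatic carbon gives a number 21 percentage points lower from compound 2 to compound 4 (beyond the scatter). For the compounds shown here, this is the first exchange here at a single place, and it shows that the group on this carbon matters for the largest response reached, something the earlier compounds, with no pair differing in one place, could not show. The step is also wider than the spread between repeat entries of one compound: the several entries of compound 1 in this assay, 87%; 83% (2 entries)

With a single exchange, the data cannot tell whether the step follows from the hydrogen-bond acceptor that leaves with methoxymethyl or from the smaller number of heavy atoms. As far as these compounds go, how a hydroxymethyl group or an amine on this aromatic carbon would behave stays open, as does whether the same exchange would act alike on the core of compound 1.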